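Dissociation notes: quinoline-core diamines, aryl change at ring carbon

The compounds below may be only part of what the source reports. "The series", "measured", "known", "first", "only" and "open" are said of these compounds alone.

Compound 1 `COc1ccc(F)cc1CNCCCNc1ccnc2cc(Oc3ccc(F)cc3)ccc12` in a physicochemical assay for acid dissociation, gives 9.28.
Compound 2 `COc1ccc(F)cc1CNCCCNc1ccnc2cc(Oc3cccc(N(C)C)c3)ccc12` in this assay gives 9.28.
Compound 3 `COc1ccc(F)cc1CNCCCNc1ccnc2cc(CCC(C)C)ccc12` in this assay gives 9.47.

Compound 3 holds the highest of the three numbers, but a number 0.19 log units higher from compound 1 to compound 3 (within the scatter) and a number 0.19 log units higher from compound 2 to compound 3 (within the scatter) both lie within the scatter, so no order among the three is claimed. Compound 4 `COc1ccc(F)cc1CNCCCNc1ccnc2cc(-c3cccc4ccccc34)ccc12` differs from compound 3 by naphthalen-1-yl in place of isopentyl on an aromatic carbon. For the measured compounds named here, the steps that bear on this position are no change at the digits printed from compound 1 to compound 2 (within the scatter), a number 0.19 log units higher from compound 1 to compound 3 (within the scatter) and a number 0.19 log units higher from compound 2 to compound 3 (within the scatter), none beyond the scatter. Every exchange at this carbon so far has left the read-out flat, so the expected step is a number 0.07 log units lower from compound 3 to compound 4 (within the scatter), no change beyond the scatter. For compound 4 the estimate is 9.4, with a range from 9.1 to 9.7.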

Compound 4, acid dissociation constant: 9.47
For compound 4 the middle estimate is 0.07 log units below the measured one; measured number inside the range.
By their numbers in this assay, from the lowest: compounds 1, 2, 3 and 4 (each within the scatter of the next).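

In this assay, naphthalen-1-yl on this aromatic carbon shows no change at the digits printed from compound 3 to compound 4 (within the scatter) and, against the two phenoxy groups, a number 0.19 log units higher from compound 2 to compound 4 (within the scatter) and a number 0.19 log units higher from compound 1 to compound 4 (within the scatter) at this position. A fused aryl group attached directly, with no oxygen link, therefore joins the isopentyl chain and the phenoxy groups in leaving the read-out flat across compound 1, compound 2, compound 3 and compound 4. Nothing on hand explains this flatness. From the compounds shown here alone, whether a carboxylic acid or a primary amine on this carbon would move the number beyond the scatter remains open.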